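From a methoxyphenyl to a dichlorophenyl on a ring nitrogen

The source may report more compounds than this note shows. Statements on the series, on what has been measured and on what is new or still open speak of the compounds shown alone.

compound 1 `CCC1(CCCCN2CC=C(c3ccc(Cl)cc3)CC2)C(=O)Nc2ccccc21`: > 20 mg/kg
compound 2 `CCC1(CCCCN2CCN(c3ccc(OC)cc3)CC2)C(=O)Nc2ccccc21`: > 20 mg/kg
compound 3 `CCC1(CCCN2CCN(c3cccc(Cl)c3)CC2)C(=O)Nc2ccccc21`: > 20 mg/kg

In a functional assay on the whole organism (strain Wistar) with Rattus norvegicus as the target, with a stated time of 5 min (a lower number here means that less compound is needed, a higher number that more compound is needed for the effect), compound 1 gives only a limit, > 20 mg/kg. Compound 2 likewise gives only a limit, > 20 mg/kg. Compound 3 too gives only a limit, > 20 mg/kg. Compound 2 therefore stands exactly where every measured value stands: the limit of > 20 mg/kg in this assay, at which 3 of the 3 values shown sit. Among the measured compounds shown here, no two measured compounds differ in just one place, so no step can be read from them. Compound 4 `CCC1(CCCCN2CCN(c3ccc(Cl)c(Cl)c3)CC2)C(=O)Nc2ccccc21` is not yet measured; it differs from compound 2 by 3,4-dichlorophenyl in place of 4-methoxyphenyl on an amine nitrogen in a ring. For the measured compounds named here, with three limits and no measured step, the expected change from compound 2 to compound 4 is a step that the limit leaves unreadable from compound 2 to compound 4, that is, none beyond the scatter. Compound 4 is expected to need about 25 mg/kg, between 8 mg/kg and 60 mg/kg, most likely reported as a limit again.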

Compound 4, minimum effective dose: > 20 mg/kg
Compound 4 gave a limit, no number (the forecaster's own chance of this, stated with the estimate: 70%); the middle value lies beyond the limit too.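

No step can be read for 3,4-dichlorophenyl in place of 4-methoxyphenyl, since compound 2 and compound 4 both give only a limit in this assay: the limit of > 20 mg/kg in this assay, at which 4 of the 4 values shown sit.

On these data alone, whether any of the four compounds has a measurable minimum effective dose, and how these two groups compare, stays open.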